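Aminoalkyl chain replacing phenylethyl on the shared core

The source may hold more compounds than are shown below. What is called first, only, known or untested is meant among the compounds shown, and "the series" means these compounds.

The shared core of compound 1 `C[C@@H](Nc1c(C(=O)NCc2ccc(F)cc2)nc(Br)c2cccnc12)c1ccccc1` carries a 1-phenylethyl group on a nitrogen on an aromatic ring. In a functional assay on HCT-116 cells (Homo sapiens) for cytotoxicity, read by MTT assay, with a stated time of 72 h (on this read-out lower numbers stand for stronger inhibition and higher numbers for weaker inhibition), compound 1 returns only a limit, > 20000 nM, so its true number is not known. Compound 2 `N[C@H]1CC[C@H](Nc2c(C(=O)NCc3ccc(F)cc3)nc(Br)c3cccnc23)CC1` places a 4-aminocyclohexyl group at that nitrogen, and in this assay compound 2 gives 4000 nM. Compound 3 `COC(=O)CNc1c(C(=O)NCc2ccc(F)cc2)nc(Br)c2cccnc12` carries a (methoxycarbonyl)methyl group there. In this assay compound 3 reaches only a limit, > 10000 nM.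

Among these, the step of an at least 5.0-fold lower number from compound 1 to compound 2 (0.69 log units; beyond the scatter) shows that an amine-bearing substituent on that nitrogen lowers the number at least modestly, while the step of an at least 2.5-fold higher number from compound 2 to compound 3 (0.39 log units; beyond the scatter) shows the ester-bearing group falling back toward the limits; the step that the two limits leave unreadable from compound 1 to compound 3 cannot be read because both ends are limits (the limit of > 10000 nM in this assay, at which 1 of the 3 values shown sits, (the limit of > 20000 nM in this assay, at which 1 of the 3 values shown sits)).

Compound 4 `NCCCCCCNc1c(C(=O)NCc2ccc(F)cc2)nc(Br)c2cccnc12` differs from compound 1 as follows: 6-aminohexyl in place of 1-phenylethyl on a nitrogen on an aromatic ring. The 6-aminohexyl group, like the 4-aminocyclohexyl group of compound 2, brings a hydrogen-bond donor and acceptor, so compound 4 is expected to sit closer to compound 2 than to the limit of compound 1, with the expected step of an at least 3.3-fold lower number from compound 1 to compound 4 (0.52 log units; beyond the scatter). Compound 4 is therefore estimated at 6000 nM, within the range 2000 nM to 20000 nM.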

Compound 4, half-maximal inhibitory concentration: > 10000 nM
Compound 4 gave a limit, no number; the forecaster's own chance of this, stated with the estimate: 30%; at least 1.6-fold (0.22 log units) between middle value and limit.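

In this assay, replacing the 4-aminocyclohexyl group with the open 6-aminohexyl chain gives an at least 2.5-fold higher number from compound 2 to compound 4 (0.39 log units; beyond the scatter) and so shows that an amine on the substituent at this nitrogen does not by itself bring the lower number seen for compound 2. Among the four compounds shown, compound 2 is the only one that returns a number rather than a limit, so the gain at this position goes with the 4-aminocyclohexyl group and not with every amine-bearing group. The steps to compound 4 from compound 1 and from compound 3 cannot be read, since both ends of each are limits: the limit of > 10000 nM in this assay, at which 2 of the 4 values shown sit, and (the limit of > 20000 nM in this assay, at which 1 of the 4 values shown sits).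

The compounds shown leave open whether a shorter or longer aminoalkyl chain, or a plain cyclohexyl group without the amine, would give a number at this nitrogen, and so whether the ring, the amine or both together go with the result for compound 2. They also leave open whether a carboxylic acid in place of the methyl ester of compound 3 would move the read-out away from the limit.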